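Methoxy added to compound 2 at the assay limit

The source may hold more compounds than are shown below. What is called first, only, known or untested is meant among the compounds shown, and "the series" means these compounds.

Measured in a functional assay on Ramos cells (Homo sapiens) for antiproliferative activity, read by CCK-8 assay, with a stated time of 48 h; a higher number here means a weaker inhibitor, a lower number a stronger inhibitor:
compound 1 `C=CC(=O)Nc1cccc(-n2cnc3cnc(Nc4ccc(N5CCN(CC)CC5)cc4OC)nc32)c1`: > 40000 nM
compound 2 `C=CC(=O)Nc1cccc(-n2cnc3cnc(Nc4ccc(N5CCN(S(C)(=O)=O)CC5)cc4)nc32)c1`: > 40000 nM
compound 3 `C=CC(=O)Nc1cccc(-n2cnc3cnc(Nc4ccc(N5CCN(C(C)=O)C(C)C5)cc4)nc32)c1`: > 40000 nM

Compound 2 gives > 40000 nM, which is a limit of the assay and not a number. The series offers no numerical value to place it against: the limit of > 40000 nM in this assay, at which 3 of the 3 values shown sit. The next compound is compound 4 `C=CC(=O)Nc1cccc(-n2cnc3cnc(Nc4ccc(N5CCN(S(C)(=O)=O)CC5)cc4OC)nc32)c1`, and its difference from compound 2 is methoxy in place of hydrogen on an aromatic carbon. Within the data shown here, the only measured step is a step that the two limits leave unreadable from compound 2 to compound 3. That step changes the piperazine substituent, leaves the methoxy question untouched and gives no size to carry over. Compound 1 also carries a methoxy group, alongside a different piperazine substituent. Compound 1 gives > 40000 nM, which is again a limit. Among the measured compounds shown here, no measured step isolates the methoxy group, so no direction can be firmly assigned in this assay, and compound 4 is expected to stay near the limit, most likely reported only as one. The expected change is an at least 1.1-fold lower number from compound 2 to compound 4 (0.05 log units; that floor lies within the scatter). Compound 4 is estimated at 35000 nM, with an expected range of 10000 nM to 60000 nM.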

Compound 4, half-maximal inhibitory concentration: 38600 nM
Estimate against measurement, compound 4: 1.1-fold (0.04 log units) below; the range from low to high includes it.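

In this assay, methoxy in place of hydrogen on this aromatic carbon, ortho to a large group, gives an at least 1.0-fold lower number from compound 2 to compound 4 (0.01 log units; that floor lies within the scatter). With the methoxy group held in place, methylsulfonyl in place of ethyl on an amine nitrogen in a ring gives an at least 1.0-fold lower number from compound 1 to compound 4 (0.01 log units; that floor lies within the scatter). Compound 4 gives 38600 nM, so among the compounds shown only the pairing of methoxy and methylsulfonyl gives a number, though neither step can be read as a gain, and the other three compounds remain at: the limit of > 40000 nM in this assay, at which 3 of the 4 values shown sit.

On these data alone, the true size of both steps stays open, as compound 1 and compound 2 are held only by limits. Also open, as far as these compounds go, is whether an ethoxy group or an amine on this aromatic carbon would move the value of compound 4 beyond the scatter.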